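Adding an ethyl group to the weakest of three analogues

The source may hold more compounds than are shown below. What is called first, only, known or untested is meant among the compounds shown, and "the series" means these compounds.

Going by the values given here, compound 3 `Nc1nc(N)c2nc(CCc3ccc(C(=O)NC(CCC(=O)O)C(=O)O)cn3)cnc2n1` is measured in a functional assay on L1210 cells (Mus musculus) (a higher number here means a weaker inhibitor, a lower number a stronger inhibitor), at 88 nM, the highest number among the three compounds measured so far, so it is the weakest inhibitor of that set. Compound 1 `Nc1nc(N)c2nc(CCc3ccc(C(=O)NC(CCC(=O)O)C(=O)O)s3)cnc2n1` gives 8.1 nM in this assay, and compound 2 `CCC(Cc1cnc2nc(N)nc(N)c2n1)c1ccc(C(=O)NC(CCC(=O)O)C(=O)O)s1` gives 3.7 nM. Compound 4 `CCC(Cc1cnc2nc(N)nc(N)c2n1)c1ccc(C(=O)NC(CCC(=O)O)C(=O)O)cn1` has not yet been measured; it differs from compound 3 by ethyl in place of hydrogen on a saturated chain carbon bound to an aromatic carbon and a saturated chain carbon. Among the compounds with values here, one measured step bears directly on this change: the same replacement, made on the closely related pair, gave a 2.2-fold lower number from compound 1 to compound 2 (0.34 log units; beyond the scatter), a modest gain in potency that lies beyond the usual scatter. Because the closely related pair gave a 2.2-fold lower number from compound 1 to compound 2 (0.34 log units; beyond the scatter) for the same change on an otherwise unaltered framework, a step of similar size and in the same direction is expected here, namely a 2.2-fold lower number from compound 3 to compound 4 (0.34 log units; beyond the scatter). The estimate for compound 4 in this assay is 40 nM, with an expected range from 15 nM to 110 nM.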

Compound 4, half-maximal inhibitory concentration: 268 nM
Estimate against measurement, compound 4: 6.7-fold (0.83 log units) below; measured number above the stated range.
By their numbers in this assay, from the lowest: compound 2; then compound 1; then compound 3; then compound 4.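

On the core of compound 3, ethyl in place of hydrogen on this saturated chain carbon gives a 3.0-fold higher number from compound 3 to compound 4 (0.48 log units; beyond the scatter) in this assay, so here the change weakens inhibition, whereas on the core of compound 1 it strengthened it. The effect of the ethyl at this position therefore depends on the core that carries it, as the gap between the two steps shows: the same change on two cores in this assay, a 2.2-fold lower number (0.34 log units; beyond the scatter) from compound 1 to compound 2 and a 3.0-fold higher number (0.48 log units; beyond the scatter) from compound 3 to compound 4, 6.7-fold (0.82 log units) apart, beyond the scatter of two such steps A step measured on one core thus cannot simply be carried over to the other, even for an identical change at the same position.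

Why the two cores respond in opposite directions remains unknown, and only hydrogen and ethyl are shown at this carbon. A methyl or a longer chain such as propyl on each core could show whether either effect changes with chain length.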